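Methylsulfanyl for methoxy on a quinazoline-series benzylamine

The source may report more compounds than this note shows. Statements on the series, on what has been measured and on what is new or still open speak of the compounds shown alone.

Measured compounds:
compound 1, `COc1ccc(CNc2nc([SeH])nc3ccccc23)cc1`, 71300 nM
compound 2, `CSc1ccc(CNc2nc([SeH])nc3ccccc23)cc1`, 6840 nM
compound 3, `COc1ccc(CNc2nc(SC)nc3ccccc23)cc1`, 85600 nM

The three measured compounds were run in an ADME assay on 184B5 cells (Homo sapiens) for cytotoxicity, read by MTT assay, with a stated time of 72 h; a higher number here means a weaker inhibitor of growth, a lower number a stronger inhibitor of growth. Compound 1 gives 71300 nM, compound 2 gives 6840 nM, and compound 3 gives 85600 nM in this assay.

Compound 1 and compound 2 differ by one change, (methylsulfanyl in place of methoxy on an aromatic carbon), and the step it made was a 10-fold lower number from compound 1 to compound 2 (1.02 log units; beyond the scatter). Compound 1 and compound 3 differ in their cores by a group of 2 heavy atoms (1 carbon, 1 sulfur; no ring) in place of one selenium atom, on an aromatic carbon, a step of a 1.2-fold higher number from compound 1 to compound 3 (0.08 log units; within the scatter), so the two cores behave alike within the measured scatter.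

Compound 4, `CSc1ccc(CNc2nc(SC)nc3ccccc23)cc1`, has not yet been measured. It differs from compound 3 by methylsulfanyl in place of methoxy on an aromatic carbon. The place of this change is described in the same words as the place of the change from compound 1 to compound 2, so it is the same change, made on the core of compound 3 rather than on the core of compound 1. Since the core difference gave a step of only a 1.2-fold higher number from compound 1 to compound 3 (0.08 log units; within the scatter), the change is expected to act in this assay much as it did before, and the step from compound 3 to compound 4 is estimated as a 9.5-fold lower number from compound 3 to compound 4 (0.98 log units; beyond the scatter), beside the earlier 10-fold lower number from compound 1 to compound 2 (1.02 log units; beyond the scatter). For compound 4 the expected value is therefore 9000 nM, with a range from 3000 nM to 30000 nM.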

Compound 4, concentration for 50% growth inhibition: 22000 nM
Beside the measured number, compound 4's estimate is 2.4-fold (0.39 log units) below it; the range from low to high includes it.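

In this assay, methylsulfanyl in place of methoxy lowered the number on the core of compound 3 as it had on the core of compound 1, with a step of a 3.9-fold lower number from compound 3 to compound 4 (0.59 log units; beyond the scatter), so the direction carried over but the size did not: the same change on two cores in this assay, a 10-fold lower number (1.02 log units; beyond the scatter) from compound 1 to compound 2 and a 3.9-fold lower number (0.59 log units; beyond the scatter) from compound 3 to compound 4, 2.7-fold (0.43 log units) apart, beyond the scatter of two such steps. The core difference, read the other way, gives the same picture: it made no difference that could be told from scatter on the methoxy compounds, yet on the methylsulfanyl compounds it gave a step of a 3.2-fold higher number from compound 2 to compound 4 (0.51 log units; beyond the scatter), so the two cores cannot be treated as interchangeable for this change: the same change on two cores in this assay, a 1.2-fold higher number (0.08 log units; within the scatter) from compound 1 to compound 3 and a 3.2-fold higher number (0.51 log units; beyond the scatter) from compound 2 to compound 4, 2.7-fold (0.43 log units) apart, beyond the scatter of two such steps. These four compounds show that the two changes do not simply add up in this assay, but they do not show what lies behind the gap, and a single pair of cores cannot show whether a smaller step on one core would recur on any other.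

The compounds shown leave open how other groups would behave in the place of the methoxy, such as an amine, a chlorine atom or a longer chain on the sulfur. They also leave open whether the core of compound 3 would blunt those groups as it did the methylsulfanyl group.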